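Removing a Ring Methyl: Expected Permeability of Compound 4

This account rests on a few compounds, and the source may have more. Where it says the series, first, only, none or still open, it means among the compounds named here.

Of the compounds shown here, three sharing one core have been measured in an ADME assay on Caco-2 cells (Homo sapiens) for permeability, in the apical to basolateral direction, at pH 7.4; a higher number here means that the compound crosses the layer faster, a lower number that the compound crosses the layer more slowly. Compound 1 `Cc1ccc2[nH]c(C(=O)N[C@H]3CN(S(=O)(=O)c4ccccc4)C[C@@H]3C(=O)NC[C@H]3CCCN3)cc2c1` gives 0.11 10^-6 cm/s, and compound 2 `Cc1ccc2[nH]c(C(=O)N[C@H]3CN(S(=O)(=O)c4ccccc4)C[C@@H]3C(=O)NC[C@H]3CCCN3C)cc2c1` gives 0.08 10^-6 cm/s. Compound 3 `Cc1ccc2[nH]c(C(=O)N[C@H]3CN(S(=O)(=O)c4ccccc4)C[C@@H]3C(=O)N[C@@H]3CCCN(C)C3)cc2c1` gives 0.76 10^-6 cm/s, the highest of the three numbers; the steps of a 6.9-fold higher number from compound 1 to compound 3 (0.84 log units; beyond the scatter) and a 9.5-fold higher number from compound 2 to compound 3 (0.98 log units; beyond the scatter) both lie beyond the scatter. Compound 4 `Cc1ccc2[nH]c(C(=O)N[C@H]3CN(S(=O)(=O)c4ccccc4)C[C@@H]3C(=O)N[C@H]3CCCNC3)cc2c1` has not yet been measured. It differs from compound 3 by piperidin-3-yl in place of 1-methylpiperidin-3-yl on an amide-type nitrogen. For the measured compounds named here, the one measured step of the same kind, taken in the opposite direction, is a 1.4-fold lower number from compound 1 to compound 2 (0.14 log units; within the scatter), and it lies within the scatter. On that basis no change beyond the scatter is expected, and the estimated step is a 1.3-fold lower number from compound 3 to compound 4 (0.10 log units; within the scatter). Compound 4 is therefore expected to give about 0.6 10^-6 cm/s, with a range from 0.25 10^-6 cm/s to 1.5 10^-6 cm/s.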

Compound 4, apparent permeability: 0.04 10^-6 cm/s
Compound 4: the middle estimate sits 15-fold (1.18 log units) above what was measured; measured number outside the range, below it.
By their numbers in this assay, from the lowest: compounds 4, 2 and 1 (each within the scatter of the next, the first and the last beyond it); then compound 3.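

Going from 1-methylpiperidin-3-yl to piperidin-3-yl on the amide-type nitrogen gives a 19-fold lower number from compound 3 to compound 4 (1.28 log units; beyond the scatter), whereas the same loss of a ring methyl barely registered in the earlier pair. With a 2.0-fold lower number from compound 2 to compound 4 (0.30 log units; within the scatter) and a 2.8-fold lower number from compound 1 to compound 4 (0.44 log units; beyond the scatter), the piperidin-3-yl ring alone does not bring the high number of compound 3. Nothing available explains this drop.

The two structures also draw the ring stereocentre with opposite handedness, so the methyl and the handedness remain unseparated. On these data alone, how an ethyl group on that ring nitrogen would behave stays open.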